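A Methylsulfonyl Amide Variant of a Myc Binder

The source may report more compounds than this note shows. Statements on the series, on what has been measured and on what is new or still open speak of the compounds shown alone.

Compound 3 `CNC(=O)c1ccc(-c2cc(-c3ccc(C#N)cc3)nc(-c3ccco3)c2)cc1` carries no number in an assay on cells for binding affinity to Myc proto-oncogene protein (Homo sapiens); a lower number here means a stronger inhibitor, a higher number a weaker inhibitor; its entry reads "not determined" (no result reported). Compound 4 `CS(=O)(=O)NC(=O)c1ccc(-c2cc(-c3ccc(C#N)cc3)nc(-c3ccco3)c2)cc1` differs from it by methylsulfonyl in place of methyl on an amide-type nitrogen. For the measured compounds named here, the only measured step touches the same end of the molecule: in this assay compound 1 `N#Cc1ccc(-c2cc(-c3ccc(C(N)=O)cc3)cc(-c3ccco3)n2)cc1` gives 3000 nM and compound 2 `N#Cc1ccc(-c2cc(-c3ccccc3)cc(-c3ccco3)n2)cc1` gives 5000 nM. The step is a 1.7-fold higher number from compound 1 to compound 2 (0.22 log units; within the scatter), so swapping carbamoyl for hydrogen on an aromatic carbon leaves the number essentially where it was. Nothing measured speaks directly to a methylsulfonyl on the amide-type nitrogen, and no size or direction can be read off for that step in this assay beyond the scatter. Compound 4 is therefore expected near 4000 nM, with a wide range from 1000 nM to 15000 nM.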

Compound 4, half-maximal inhibitory concentration: 10000 nM
For compound 4 the middle estimate is 2.5-fold (0.40 log units) below the measured one; the range from low to high includes it.
By their numbers in this assay, from the lowest: compounds 1, 2 and 4 (each within the scatter of the next, the first and the last beyond it).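

For the compounds shown here, putting methylsulfonyl on the amide-type nitrogen produces the first change that clears the scatter in this assay (a 3.3-fold higher number from compound 1 to compound 4 (0.52 log units; beyond the scatter)), so this nitrogen is not indifferent to what it carries. Measured against hydrogen on the aromatic carbon, the whole (methylsulfonyl)carbamoyl group makes a smaller difference (a 2.0-fold higher number from compound 2 to compound 4 (0.30 log units; within the scatter)). Nothing available accounts for either step. Still open, on these data alone, is how other groups at this place would read, such as a carboxylic acid, an amine or a longer chain on the amide-type nitrogen.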